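Cytotoxicity Held at the Ceiling Across Three Amine Chains

The source may report more compounds than this note shows. Statements on the series, on what has been measured and on what is new or still open speak of the compounds shown alone.

Measured in an ADME assay on Huh-7 cells (Homo sapiens) for cytotoxicity; on this read-out lower numbers stand for higher toxicity in this test and higher numbers for lower toxicity in this test:
Compound 1 `Cc1ccccc1-c1nn(-c2ccc(F)cc2F)cc1CNCCN1CCCCC1` gives > 20000 nM, a limit.
Compound 2 `Cc1ccccc1-c1nn(-c2ccc(F)cc2F)cc1CNCCCCO` gives > 20000 nM, a limit.
Compound 3 `CCCN1CCC(CNCc2cn(-c3ccc(F)cc3F)nc2-c2ccccc2C)CC1` gives > 20000 nM, a limit.

Compound 3 thus stands where every measured compound stands: the limit of > 20000 nM in this assay, at which 3 of the 3 values shown sit. Its neighbour compound 4 `Cc1ccccc1-c1nn(-c2ccc(F)cc2F)cc1CNCCN(C)C` differs by (dimethylamino)methyl in place of 1-propylpiperidin-4-yl on a saturated chain carbon bound to an amine nitrogen. The steps that could inform this change are a step that the two limits leave unreadable from compound 1 to compound 3, a step that the two limits leave unreadable from compound 2 to compound 3 and a step that the two limits leave unreadable from compound 1 to compound 2, and none of them yields a readable size, since both ends sit at the limit each time. No readable step is therefore expected for compound 4 either, and its estimated step is a step that the limit leaves unreadable from compound 3 to compound 4. Compound 4 is estimated at 30000 nM, within 15000 nM to 100000 nM, most likely reported again only as a limit.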

Compound 4, half-maximal cytotoxic concentration: > 20000 nM
Compound 4 ended at the assay's limit (the forecaster's own chance of this, stated with the estimate: 85%); the middle value does not contradict the limit.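

No step can be read among compound 1, compound 2, compound 3 and compound 4, since each gives only a limit and not a number: the limit of > 20000 nM in this assay, at which 4 of the 4 values shown sit.

The compounds shown leave open where any of the four truly lies beyond that limit, and so whether these amine chains differ at all.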